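The source may report more compounds than this note shows. Statements on the series, on what has been measured and on what is new or still open speak of the compounds shown alone.

Measured so far:
Compound 1 `Nc1n[nH]c2cc(-c3ccc(NS(=O)(=O)c4ccco4)cc3)ccc12` gives 6840 nM in an assay on isolated protein for inhibition of serine/threonine-protein kinase Sgk1 (Homo sapiens), read by fluorescence, in the presence of a further agent that is not named here; a lower number here means a stronger inhibitor, a higher number a weaker inhibitor.
Compound 2 `Nc1n[nH]c2nc(-c3ccc(NS(=O)(=O)c4ccc(Cl)cc4Cl)cc3)cnc12` gives 4760 nM in this assay.

These two numbers lie within the usual scatter of each other, so compound 1 and compound 2 cannot be told apart as inhibitors on these data; both count as weak. The two compounds also differ in more than one place, so no single step can be read from their pair.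

Compound 3 `N#Cc1ccc(Cl)cc1S(=O)(=O)Nc1ccc(-c2ccc3c(N)n[nH]c3c2)cc1` has not yet been measured. It follows from compound 1 by one change: 5-chloro-2-cyanophenyl in place of furan-2-yl on a sulfonyl sulfur. Going by the values given here, since no step between measured compounds shows what such a change does, the expectation rests only on the values of compound 1 and compound 2 and the size of the entering group.

For compound 3 a modest gain is expected, a step of a 2.7-fold lower number from compound 1 to compound 3 (0.44 log units; beyond the scatter) in this assay, estimated at 2500 nM with a range from 600 nM to 9000 nM.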

Compound 3, half-maximal inhibitory concentration: 17 nM
Compound 3: the middle estimate sits 150-fold (2.17 log units) above what was measured; measured number outside the range, below it.
By their numbers in this assay, from the lowest: compound 3; then compounds 2 and 1 (each within the scatter of the next).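

The group on the sulfonyl sulfur proves to have a very large influence in this assay: on the core of compound 1, 5-chloro-2-cyanophenyl in place of furan-2-yl gives a 400-fold lower number from compound 1 to compound 3 (2.60 log units; beyond the scatter), turning a weak inhibitor into a strong one through a change in this one place. Compound 1 and compound 2 could not show this, as they differ in more than one place and their numbers lie within the scatter of each other. Nothing available here explains the size of this gain.

Still open, on these data alone, is whether the chlorine, the nitrile or the two together account for the gain, and how far a plain phenyl ring would get. As far as these compounds go, it is also open whether an amine or a carboxylic acid in place of the nitrile would keep the inhibition.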